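Quaternary piperidinium series: ester in place of nitrofuran

The source may report more compounds than this note shows. Statements on the series, on what has been measured and on what is new or still open speak of the compounds shown alone.

For the measured compounds named here, compound 3 `COc1cc2cc(C(=O)CCC3CC[N+](C)(Cc4ccc([N+](=O)[O-])o4)CC3)sc2cc1OC` gives 600 ug/mL in a physicochemical assay for solubility (on this read-out higher numbers stand for higher solubility and lower numbers for lower solubility), the lowest of the three numbers measured so far. Compound 1 `COc1cc2cc(C(=O)CCC3CC[N+](C)(Cc4ccccc4)CC3)sc2cc1OC` gives 2000 ug/mL in this assay, and compound 2 `COC(=O)C[N+]1(C)CCC(CCC(=O)c2cc3cc(OC)c(OC)cc3s2)CC1` gives 60000 ug/mL. The step of a 3.3-fold lower number from compound 1 to compound 3 (0.52 log units; beyond the scatter) is modest; the step of a 100-fold lower number from compound 2 to compound 3 (2.00 log units; beyond the scatter) is large, and the step of a 30-fold higher number from compound 1 to compound 2 (1.48 log units; beyond the scatter) is large as well.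

Compound 4 `COc1cc2cc(C(=O)CCC3CC[N+](C)(CC(=O)OC(C)(C)C)CC3)sc2cc1OC` has not been measured. It differs from compound 3 by tert-butoxycarbonyl in place of 5-nitrofuran-2-yl on a saturated chain carbon bound to an amine nitrogen in a ring. Going by the values given here, the measured step that bears on it most directly is a 100-fold lower number from compound 2 to compound 3 (2.00 log units; beyond the scatter), read in reverse: the group that enters in compound 4 is again an ester on the same carbon, differing from the one in compound 2 only in the alkoxy part, tert-butyl instead of methyl. The step of a 30-fold higher number from compound 1 to compound 2 (1.48 log units; beyond the scatter) points the same way, a large rise when an ester replaces an aromatic ring at that place. Among the compounds with values here, no measured pair sets a tert-butyl ester against a methyl ester, so the full size of the reversal is uncertain. A large rise in this assay is expected, the step of a 25-fold higher number from compound 3 to compound 4 (1.40 log units; beyond the scatter), though probably short of a complete return. Compound 4 is therefore estimated at 15000 ug/mL, with a range from 4000 ug/mL to 60000 ug/mL.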

Compound 4, solubility: 1500 ug/mL
For compound 4 the middle estimate is 10-fold (1.00 log units) above the measured one, and the stated range ends above it.
By their numbers in this assay, from the lowest: compound 3; then compounds 4 and 1 (each within the scatter of the next); then compound 2.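

In this assay, the ester function at this place does not settle the read-out by itself: the alkoxy part also counts, since tert-butyl in place of methyl on an oxygen next to a carbonyl group gives a 40-fold lower number from compound 2 to compound 4 (1.60 log units; beyond the scatter), so the large rise seen with methoxycarbonyl does not carry over to tert-butoxycarbonyl. Set against the aromatic groups, tert-butoxycarbonyl in place of 5-nitrofuran-2-yl gives only a 2.5-fold higher number from compound 3 to compound 4 (0.40 log units; beyond the scatter), and the step against phenyl is a 1.3-fold lower number from compound 1 to compound 4 (0.12 log units; within the scatter), which places compound 4 with compound 1 and far from compound 2, so the absence of a ring in this group does not separate it from phenyl in this series. The data at hand offer no measurement that accounts for the gap between the two esters.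

Open, on these data alone, is whether the high number of compound 2 belongs to methoxycarbonyl alone or extends to an ethyl or isopropyl ester, which would show how the read-out runs from methyl to tert-butyl. Also open, as far as these compounds go, is how a carboxylic acid or a primary amide on the same saturated chain carbon would compare with these esters.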